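This account rests on a few compounds, and the source may have more. Where it says the series, first, only, none or still open, it means among the compounds named here.

Measured so far in a functional assay on MCF7 cells (Homo sapiens) for inhibition, read by sulforhodamine B assay; a lower number here means a stronger inhibitor of growth, a higher number a weaker inhibitor of growth:

compound 1 `COc1ccc(-c2ccc(-c3ccc(-c4nc5cc(C)ccc5[nH]4)cc3)cc2)cc1OC`: 190 nM
compound 2 `Oc1cccc2[nH]c(-c3ccc(-c4ccc(-c5ccccc5)cc4)cc3)nc12`: 2200 nM
compound 3 `COc1ccc(-c2ccc(-c3ccc(-c4nc5c(O)cccc5[nH]4)cc3)cc2)cc1OC`: 190 nM

Compound 1 and compound 3 give the same number at the digits printed. Their cores differ by 5-methyl-1H-benzimidazol-2-yl in place of 4-hydroxy-1H-benzimidazol-2-yl on an aromatic carbon, and the step of no change at the digits printed from compound 1 to compound 3 (within the scatter) is within the scatter, so the two cores behave alike in this assay with the rest of the molecule held constant. Between compound 3 and compound 2 the change is phenyl in place of 3,4-dimethoxyphenyl on an aromatic carbon, and it made a large step: a 12-fold higher number from compound 3 to compound 2 (1.06 log units; beyond the scatter). Compound 3 and compound 1 stand together as the lowest pair of the three numbers, with compound 2 well above both.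

Compound 4 `Cc1ccc2[nH]c(-c3ccc(-c4ccc(-c5ccccc5)cc4)cc3)nc2c1` is not yet measured in this assay. It differs from compound 1 by phenyl in place of 3,4-dimethoxyphenyl on an aromatic carbon. This is the same change, at the same place, as that from compound 3 to compound 2; the two place descriptions match word for word. The series thus offers one measured instance of the change and a second, unmeasured one on a core that has already been shown to be equivalent.

The step of a 12-fold higher number from compound 1 to compound 4 (1.06 log units; beyond the scatter) is expected to be close in size to a 12-fold higher number from compound 3 to compound 2 (1.06 log units; beyond the scatter), because no change at the digits printed from compound 1 to compound 3 (within the scatter) shows that the two cores are level and gives no reason for the change to read differently on the core of compound 1. Compound 4 is therefore estimated at 2200 nM in this assay. The range expected for compound 4 runs from 900 nM to 5500 nM, allowing for the scatter on both measured ends of the transferred step.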

Compound 4, concentration for 50% growth inhibition: 31600 nM
Beside the measured number, compound 4's estimate is 14-fold (1.16 log units) below it, and the stated range ends below it.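

Phenyl in place of 3,4-dimethoxyphenyl on the core of compound 1 gives a 170-fold higher number from compound 1 to compound 4 (2.22 log units; beyond the scatter), so in this assay the direction of the change carries over from the core of compound 3, with a higher number on both. The size does not carry over: the same change on two cores in this assay, a 12-fold higher number (1.06 log units; beyond the scatter) from compound 3 to compound 2 and a 170-fold higher number (2.22 log units; beyond the scatter) from compound 1 to compound 4, 14-fold (1.16 log units) apart, beyond the scatter of two such steps With phenyl in place, the two cores no longer stand level, as compound 2 gives 2200 nM and compound 4 gives 31600 nM, so cores that match while bearing 3,4-dimethoxyphenyl need not match once it is changed, although two pairs show neither why the steps differ nor how far this holds beyond compounds 1 to 4.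

Open, from the compounds shown here alone, is how large the step would be on further cores, for instance one with an amine or a carboxylic acid where the core of compound 3 has its hydroxyl and the core of compound 1 has its methyl, or one with neither group. Also open, going by these compounds, is whether a phenyl with a single methoxy group, or with a longer ether chain, would read nearer to the 3,4-dimethoxyphenyl compounds or to the phenyl compounds on each core.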